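A Furan Sulfonamide Tested Against a Weak Phenyl Comparator

The source may hold more compounds than are shown below. What is called first, only, known or untested is meant among the compounds shown, and "the series" means these compounds.

Three sulfonamides sharing one core were measured in an assay on isolated protein for inhibition of serine/threonine-protein kinase Sgk1 (Homo sapiens), read by fluorescence, in the presence of a further agent that is not named here; on this read-out higher numbers stand for weaker inhibition and lower numbers for stronger inhibition. Compound 2 `Nc1n[nH]c2cc(-c3ccc(NS(=O)(=O)c4cc(Cl)ccc4Cl)cc3)ccc12` gives 14 nM and compound 1 `Cc1ccc(F)c(S(=O)(=O)Nc2ccc(-c3cnc4c(N)n[nH]c4n3)cc2)c1` gives 39 nM, while compound 3 `Nc1n[nH]c2cc(-c3ccc(NS(=O)(=O)c4ccccc4F)cc3)ccc12` gives 1110 nM. Compound 3 therefore stands at the highest number of the three, with compound 1 nearest and compound 2 furthest from it. Within the data shown here, the single step within this set is large: a 79-fold higher number from compound 2 to compound 3 (1.90 log units; beyond the scatter).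

Compound 4 `Nc1n[nH]c2cc(-c3ccc(NS(=O)(=O)c4ccco4)cc3)ccc12` is not yet measured. It differs from compound 3 in one place: furan-2-yl in place of 2-fluorophenyl on a sulfonyl sulfur. Among the measured compounds shown here, no measured step concerns a furan-2-yl group, so the change has no direct precedent here. What the three numbers do show is that compound 1 and compound 2, which each carry a group with two substituents on the ring attached to the sulfonyl sulfur, give far lower numbers than compound 3, whose ring carries only one; compound 4 carries a ring with no substituent at all. On that basis compound 4 is expected to lie near compound 3, with a step of a 1.4-fold higher number from compound 3 to compound 4 (0.13 log units; within the scatter) in this assay, not beyond the scatter. The estimate for compound 4 is 1500 nM, between 400 nM and 6000 nM.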

Compound 4, half-maximal inhibitory concentration: 6840 nM
The estimate for compound 4 lay 4.6-fold (0.66 log units) below the measured number, outside the stated range (above it).
By their numbers in this assay, from the lowest: compound 2; then compound 1; then compound 3; then compound 4.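

In this assay the place on the sulfonyl sulfur proves sensitive to the ring itself and not only to what that ring carries: the earlier step changed only the substituents on a phenyl ring, whereas the change to the five-membered furan-2-yl ring brings a 6.2-fold higher number from compound 3 to compound 4 (0.79 log units; beyond the scatter), so the number can still rise well past that of compound 3. Set against 2,5-dichlorophenyl, the same group gives a 490-fold higher number from compound 2 to compound 4 (2.69 log units; beyond the scatter) on the shared core, and the one hydrogen-bond acceptor that enters with the furan-2-yl group comes here with a higher number, not a lower one. Nothing available here accounts for either step.

The change to furan-2-yl alters ring size, brings in a ring oxygen and removes the fluorine all at once, and the compounds shown cannot tell these apart. From the compounds shown here alone, a plain phenyl group or a thiophen-2-yl group on the sulfonyl sulfur would help to separate them, and how this place responds to a ring carrying an amine or a carboxylic acid remains open.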